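A few compounds are considered here, and "the series" means these few. Any claim that something is new, unique, unknown or untested is made for them only; others in the source may bear on it.

For the measured compounds named here, in a physicochemical assay for lipophilicity (on this read-out lower numbers stand for lower lipophilicity and higher numbers for higher lipophilicity), compound 1 `CC(=O)Nc1ccc2[nH]c(C)nc2c1` gives 0.61, the lowest of the three numbers measured so far. Compound 2 `CCCCC(=O)Nc1ccc2[nH]c(C)nc2c1` gives 2.11, and compound 3 `c1ccc2c(Cc3nc4ccccc4[nH]3)cccc2c1` gives 4.8. Compound 4 `CCOc1ccc2[nH]c(C)nc2c1` has not yet been measured. It differs from compound 1 by ethoxy in place of acetamido on an aromatic carbon. Going by the values given here, only one measured step offers a guide, and a loose one: propyl in place of hydrogen on a saturated chain carbon bound to a carbonyl carbon gave a number 1.50 log units higher from compound 1 to compound 2 (beyond the scatter). Among the compounds with values here, no measured step replaces the acetamido group itself. A rise of similar size is therefore expected, and the estimated step is a number 1.39 log units higher from compound 1 to compound 4 (beyond the scatter). For compound 4 the expected value is 2, with an estimated range from 1.5 to 2.5.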

Compound 4, partition coefficient: 1.93
Compound 4: the middle estimate sits 0.07 log units above what was measured, and the stated range covers the measured number.
By their numbers in this assay, from the lowest: compound 1; then compounds 4 and 2 (each within the scatter of the next); then compound 3.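

Putting ethoxy in place of acetamido on this aromatic carbon gives, in this assay, a number 1.32 log units higher from compound 1 to compound 4 (beyond the scatter) and so shows that the number at this position responds to replacing the whole group. The earlier step changed only the chain on the carbonyl side. This one removes the hydrogen-bond donor counted for acetamido, while a hydrogen-bond acceptor remains.

From the compounds shown here alone, whether an amine or a longer alkoxy chain on this same carbon would give a number near that of compound 4 stays open. Nothing available gives a reason for the rise.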